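Replacing the benzyloxy with a dichlorophenyl enone

A few compounds are considered here, and "the series" means these few. Any claim that something is new, unique, unknown or untested is made for them only; others in the source may bear on it.

Measured so far:
compound 1, `COC(=O)c1cc(-c2cccc(NC(=O)c3ccc(/C=C/C(=O)c4ccc(OC)cc4)cc3)c2)on1`: > 10 ug/mL
compound 2, `COC(=O)c1cc(-c2cccc(NC(=O)c3ccc(OCc4ccc(Cl)cc4)cc3)c2)on1`: > 80 ug/mL

Compound 2 sits at the limit of > 80 ug/mL in this assay, at which 1 of the 2 values shown sits, in an ADME assay on Vero cells (Chlorocebus sabaeus) for cytotoxicity, read by MTT assay, with a stated time of 72 h (on this read-out higher numbers stand for lower toxicity in this test and lower numbers for higher toxicity in this test), so only a limit and no number is known for it. Compound 1, in this assay, is likewise known only as a limit, at the limit of > 10 ug/mL in this assay, at which 1 of the 2 values shown sits. Among the measured compounds shown here, the one step between the two, a step that the two limits leave unreadable from compound 1 to compound 2, therefore cannot be read for size. Compound 3, `COC(=O)c1cc(-c2cccc(NC(=O)c3ccc(/C=C/C(=O)c4ccc(Cl)cc4Cl)cc3)c2)on1`, is the next compound to be tested in this assay. It differs from compound 2 by 2-((2,4-dichlorophenyl)carbonyl)ethenyl in place of (4-chlorobenzyl)oxy on an aromatic carbon. For the measured compounds named here, no measured step bears on this change with a readable size, so the direction and size of an at least 2.0-fold lower number from compound 2 to compound 3 (0.30 log units; that floor lies within the scatter) are expected only loosely. Compound 3 is estimated at 40 ug/mL, with a range from 10 ug/mL to 160 ug/mL, and the result may again come back as a limit rather than a number.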

Compound 3, half-maximal cytotoxic concentration: > 40 ug/mL
Compound 3: a limit, no number; the forecaster's own chance of this, stated with the estimate: 60%; the middle value sits exactly at the limit.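

In this assay compound 3 is known only as a limit: the limit of > 40 ug/mL in this assay, at which 1 of the 3 values shown sits.

Among the compounds shown here, with compound 1, compound 2 and compound 3 all standing as limits, no step among them can be read for size. Open remains where the half-maximal cytotoxic concentration of each compound lies, and whether these group exchanges change it at all.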